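Amide variation on the ester side chain: solubility notes

The source may hold more compounds than are shown below. What is called first, only, known or untested is meant among the compounds shown, and "the series" means these compounds.

Measured compounds:
compound 1 `CCOc1cc(NC(=O)C2(NC(=O)c3ccc4c(C5CCCC5)c(-c5ncc(Cl)cn5)n(C)c4c3)CCC2)ccc1/C=C/C(=O)OCC(N)=O`: < 200000 ug/mL
compound 2 `CCOc1cc(NC(=O)C2(NC(=O)c3ccc4c(C5CCCC5)c(-c5ncc(Cl)cn5)n(C)c4c3)CCC2)ccc1/C=C/C(=O)OCC(=O)N(C)C(C)C`: < 200000 ug/mL

In an ADME assay for solubility (a higher number here means a more soluble compound, a lower number a less soluble compound), compound 1 gives < 200000 ug/mL, a limit of the assay rather than a number. Compound 2 stands at < 200000 ug/mL, likewise a limit in this assay. Both values rest at the same limit (the limit of < 200000 ug/mL in this assay, at which 2 of the 2 values shown sit). Compound 3 `CCOc1cc(NC(=O)C2(NC(=O)c3ccc4c(C5CCCC5)c(-c5ncc(Cl)cn5)n(C)c4c3)CCC2)ccc1/C=C/C(=O)OCC(=O)N1CCCC1` differs from compound 2 by pyrrolidin-1-yl in place of isopropyl(methyl)amino on a carbonyl carbon. Among the measured compounds shown here, only one measured step bears on this change, a step that the two limits leave unreadable from compound 1 to compound 2, and it gives no readable size or direction. Compound 3 is therefore expected to remain at that limit, with a step that the limit leaves unreadable from compound 2 to compound 3 as the expected step. Compound 3 is estimated at 100000 ug/mL, from 30000 ug/mL to 200000 ug/mL.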

Compound 3, solubility: 200000 ug/mL
For compound 3 the middle estimate is 2.0-fold (0.30 log units) below the measured one; measured number inside the range.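

In this assay, among the compounds shown here, compound 3 gives 200000 ug/mL, the only actual number in this set, with pyrrolidin-1-yl on the carbonyl carbon. The ring amide reads as a number no lower from compound 2 to compound 3 (the limit leaves the size open), and against the primary amide as a number no lower from compound 1 to compound 3 (the limit leaves the size open). The other two values remain limits, not numbers: the limit of < 200000 ug/mL in this assay, at which 2 of the 3 values shown sit.

On these data alone, the true size of both steps stays open. So does the reading in this assay of amides built on piperidine or morpholine in place of pyrrolidin-1-yl.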